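Removing a Methyl Group from a Weakly Active Series

A few compounds are considered here, and "the series" means these few. Any claim that something is new, unique, unknown or untested is made for them only; others in the source may bear on it.

Measured compounds:
- Compound 1, `COCc1ncc2cnnc(SC)n12`, gives > 48000 nM in a functional assay for inhibition, with Homo sapiens as the target (a higher number here means a weaker inhibitor, a lower number a stronger inhibitor), which is a limit of the assay and not a number.
- Compound 2, `C=CCSc1nncc2cnc(CCC)n12`, gives > 48000 nM in this assay, again only a limit.
- Compound 3, `CCCc1ncc2c(C)nnc(SC)n12`, gives > 48000 nM in this assay, also a limit.

All three compounds share a core, and for none of them does this assay return a measured number. Compound 3 therefore stands at the same point as the other two: it reaches the limit described in the limit of > 48000 nM in this assay, at which 3 of the 3 values shown sit, and nothing in the data separates it from compound 1 or compound 2.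

Compound 4, `CCCc1ncc2cnnc(SC)n12`, has not yet been measured. It differs from compound 3 by hydrogen in place of methyl on an aromatic carbon, in words hydrogen in place of methyl on an aromatic carbon. Going by the values given here, no step between measured compounds is available to compare with this change. Because every value seen so far sits at the limit in the limit of > 48000 nM in this assay, at which 3 of the 3 values shown sit, the most likely outcome is that compound 4 also reaches only the limit, with no step beyond the scatter. The expected step from compound 3 to compound 4 is a step that the limit leaves unreadable from compound 3 to compound 4. Compound 4 is estimated at 60000 nM, with a range from 20000 nM to 200000 nM.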

Compound 4, half-maximal inhibitory concentration: > 48000 nM
Compound 4 ended at the assay's limit; the forecaster's own chance of this, stated with the estimate: 85%; the middle value is on the limit's open side.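

In this assay compound 4 gives > 48000 nM, which is a limit of the assay and not a number. No step linking compound 4 to compound 1, compound 2 or compound 3 can be read, because all four compounds stop at the same point: the limit of > 48000 nM in this assay, at which 4 of the 4 values shown sit.

The compounds shown leave open whether any of these changes, including hydrogen in place of methyl on an aromatic carbon, affects inhibition at all.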